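The source may report more compounds than this note shows. Statements on the series, on what has been measured and on what is new or still open speak of the compounds shown alone.

Measured in an ADME assay on microsomes from liver (Homo sapiens) for metabolic stability; a higher number here means that the compound lasts longer, a lower number that the compound disappears faster:
- compound 1 `CC#C[C@@H](Cc1nnn[nH]1)c1ccc(OCc2ccc3scc(-c4cccnc4C)c3c2)cc1`: < 0.0667 h, a limit of the assay and not a number
- compound 2 `CC#C[C@@H](Cc1nnn[nH]1)c1ccc(OCc2ccc3sc(C)c(-c4ccc(OCCOC)cc4C)c3c2)cc1`: 1.48 h

Among the measured compounds shown here, compound 2 holds the only true number here, since the other value is a limit. Compound 3 `CC#C[C@@H](Cc1nnn[nH]1)c1ccc(OCc2ccc3scc(-c4ccc(OCCOC)cc4C)c3c2)cc1` is compound 2 with hydrogen in place of methyl on an aromatic carbon of a five-membered aromatic ring with 1 sulfur, next to the ring sulfur (hydrogen in place of methyl on an aromatic carbon). For the measured compounds named here, no measured step isolates this change, so the expectation is cautious. A modest shortening of the half-life in this assay is expected, an estimated 1.9-fold lower number from compound 2 to compound 3 (0.27 log units; within the scatter). For compound 3 the estimated half-life is 0.8 h, with an expected range of 0.25 h to 1.8 h.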

Compound 3, half-life: 0.717 h
For compound 3 the middle estimate is 1.1-fold (0.05 log units) above the measured one, within the range that was stated.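

In this assay, hydrogen in place of methyl on the aromatic carbon next to the ring sulfur gives a 2.1-fold lower number from compound 2 to compound 3 (0.31 log units; beyond the scatter), so this position matters, though modestly. 4-(2-methoxyethoxy)-2-methylphenyl in place of 2-methylpyridin-3-yl gives a much larger step: an at least 10-fold higher number from compound 1 to compound 3 (1.03 log units; beyond the scatter). Compound 1 stands at a limit of the assay and not a number: the limit of < 0.0667 h in this assay, at which 1 of the 3 values shown sits.

Still open, from the compounds shown here alone, is how an ethyl group or a fluorine atom on that same carbon would compare with methyl and hydrogen. Also open, going by these compounds, is how an amine at the end of the 2-methoxyethoxy chain would change the half-life.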